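Replacing the Triple-Bonded Phenyl with a 2-Fluorophenyl

The source may hold more compounds than are shown below. What is called first, only, known or untested is meant among the compounds shown, and "the series" means these compounds.

Compound 1 `CCCCC#Cc1cc([C@@H]2O[C@H](CO)[C@@H](O)[C@H]2O)n2ncnc(N)c12` is the starting point: in a functional assay on LN-229 cells (Homo sapiens) for antiproliferative activity, with a stated time of 72 h (on this read-out lower numbers stand for stronger inhibition and higher numbers for weaker inhibition), compound 1 gives 1000 nM. Compound 3 `Nc1ncnn2c([C@@H]3O[C@H](CO)[C@@H](O)[C@H]3O)cc(C#Cc3ccccc3)c12`, which carries a phenyl in place of butyl on a triple-bonded carbon, gives 88000 nM, the highest number among those measured, and the step of an 88-fold higher number from compound 1 to compound 3 (1.94 log units; beyond the scatter) is large. Compound 2 `Nc1ncnn2c([C@@H]3O[C@H](CO)[C@@H](O)[C@H]3O)cc(C#Cc3ccc(F)cc3)c12` returns only a limit in this assay, > 100000 nM. The step of an at least 1.1-fold lower number from compound 2 to compound 3 (0.05 log units; that floor lies within the scatter) lies within the scatter. Compound 4 `Nc1ncnn2c([C@@H]3O[C@H](CO)[C@@H](O)[C@H]3O)cc(-c3ccccc3F)c12` differs from compound 3 by 2-fluorophenyl in place of 2-phenylethynyl on an aromatic carbon. Within the data shown here, no measured step removes the triple bond, so the comparisons are only loose guides; both aromatic analogues show weak inhibition. Compound 4 is therefore expected to stay weak, with an estimated step of a 1.3-fold lower number from compound 3 to compound 4 (0.10 log units; within the scatter), giving about 70000 nM (range 10000 nM to 300000 nM).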

Compound 4, half-maximal inhibitory concentration: > 100000 nM
Compound 4 ended at the assay's limit (the forecaster's own chance of this, stated with the estimate: 40%); middle value at least 1.4-fold (0.15 log units) away from the limit.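

Setting a 2-fluorophenyl directly on this aromatic carbon, with no triple bond, gives an at least 1.1-fold higher number from compound 3 to compound 4 (0.05 log units; that floor lies within the scatter) and so brings back no activity. The gap to the hex-1-yn-1-yl group stays wide, at an at least 100-fold higher number from compound 1 to compound 4 (2.00 log units; beyond the scatter) and compound 1 remains the only one of the four with a number clear of the assay's limit. Open, from the compounds shown here alone, is whether a plain hexyl chain or an amine on this carbon would keep the activity of compound 1. The step between compound 2 and compound 4 cannot be read because both values are limits: the limit of > 100000 nM in this assay, at which 2 of the 4 values shown sit.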